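Swapping a Nitro for a Bromo on a Phenol Ring

The source may report more compounds than this note shows. Statements on the series, on what has been measured and on what is new or still open speak of the compounds shown alone.

Compound 1 `COc1cc(/C=C/c2cc([N+](=O)[O-])ccc2O)cc(OC)c1OC` gives the higher of the two measured numbers: in a functional assay on MGC-803 cells (Homo sapiens) for antiproliferative activity, read by MTT assay (a higher number here means a weaker inhibitor, a lower number a stronger inhibitor), compound 1 gives 14700 nM, whereas compound 2 `COc1cccc(/C=C\c2cc(OC)c(OC)c(OC)c2)c1O` gives 1100 nM, a gap beyond the usual scatter. Compound 3 `COc1cc(/C=C/c2cc(Br)ccc2O)cc(OC)c1OC` has not been measured. It differs from compound 1 in one place: bromo in place of nitro on an aromatic carbon. Within the data shown here, no measured pair shows this exact change, so its effect cannot be read from the data. A modest step toward a stronger inhibitor is expected, about a 1.8-fold lower number from compound 1 to compound 3 (0.26 log units; within the scatter), though it may well fall within the scatter. Compound 3 is therefore estimated at 8000 nM, within a range from 2500 nM to 25000 nM.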

Compound 3, half-maximal inhibitory concentration: 4500 nM
Compound 3: middle estimate off by 1.8-fold (0.25 log units), on the high side, within the range that was stated.
By their numbers in this assay, from the lowest: compound 2; then compound 3; then compound 1.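

In this assay, bromo in place of nitro on this aromatic carbon, para to a hydroxy group, gives a 3.3-fold lower number from compound 1 to compound 3 (0.51 log units; beyond the scatter), so the number here does respond to the group at this position. The change removes 3 heavy atoms and 2 hydrogen-bond acceptors and brings in 1 heavy atom, but the two compounds cannot separate these differences. No measured property explains the step.

Still open, from the compounds shown here alone, is how an amine, a carboxylic acid or a chloro group at this position would compare with bromo.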